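Naphthyl in place of fluorophenyl on a dihydropyran core

This account rests on a few compounds, and the source may have more. Where it says the series, first, only, none or still open, it means among the compounds named here.

Compound 1: `Cc1ccc(C2C(C#N)=C(N)OC(c3c[nH]c4ccccc34)=C2C#N)cc1` gives 5.5% in a functional assay, tested at 100 ug/mL; on this read-out lower numbers stand for a weaker effect and higher numbers for a stronger effect at the one concentration tested.
Compound 2: `N#CC1=C(N)OC(c2c[nH]c3ccccc23)=C(C#N)C1c1ccc(F)cc1` gives 16.2% in this assay.

Of the compounds shown here, two have been measured in this assay. For the measured compounds named here, compound 2 stands highest of the two numbers, with compound 1 next, and the one measured step, a number 10.7 percentage points higher from compound 1 to compound 2 (beyond the scatter), is modest but beyond the scatter.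

Compound 3 is `N#CC1=C(N)OC(c2c[nH]c3ccccc23)=C(C#N)C1c1cccc2ccccc12`. It differs from compound 2 by naphthalen-1-yl in place of 4-fluorophenyl on a saturated ring carbon. Going by the values given here, no measured step swaps one aromatic ring for another, so the only known step, a number 10.7 percentage points higher from compound 1 to compound 2 (beyond the scatter), bears on this change at most indirectly: it shows that a change on the ring attached to the saturated ring carbon can move the read-out modestly, without saying in which direction a larger ring would move it.

For compound 3 the step of a number 1.2 percentage points lower from compound 2 to compound 3 (within the scatter) is therefore expected to fall within the usual scatter, and compound 3 is estimated at 15%, within 3% to 35%.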

Compound 3, a percentage reported as activity, at one concentration (the size of the read-out at that concentration, not a potency): 6.8%
The estimate for compound 3 lay 8.2 percentage points above the measured number; measured number inside the range.
By their numbers in this assay, from the lowest: compounds 1, 3 and 2 (each within the scatter of the next, the first and the last beyond it).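

In this assay, placing two six-membered aromatic rings on the saturated ring carbon, as naphthalen-1-yl in place of 4-fluorophenyl, gives a number 9.4 percentage points lower from compound 2 to compound 3 (within the scatter) and so cannot be told apart from repeat measurement. Naphthalen-1-yl in place of 4-methylphenyl gives a number 1.3 percentage points higher from compound 1 to compound 3 (within the scatter) and is equally unresolved, so the larger group leaves no clear mark when set against either single-ring compound. Nothing available here accounts for these numbers.

From the compounds shown here alone, it remains open whether naphthalen-2-yl, a cyclohexyl group or a phenyl ring carrying an amine or a carboxylic acid would shift the read-out clearly at this saturated ring carbon. For the compounds shown here, with only three groups compared at one concentration, the shared core's wider response to changes at this position also remains unknown.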